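Fluoromethyl in place of hydroxymethyl on the branched chain

The source may report more compounds than this note shows. Statements on the series, on what has been measured and on what is new or still open speak of the compounds shown alone.

Measured so far in a functional assay on HeLa cells (Homo sapiens) for cytotoxicity, read by WST assay, with a stated time of 48 h (a lower number here means a stronger inhibitor, a higher number a weaker inhibitor), for this series
- compound 1 `COc1cc(C(c2ccc(O)c(OC)c2)[C@H](CF)C(C)C)ccc1O` gives 19000 nM
- compound 2 `COC[C@@H](C(C)C)C(c1ccc(O)c(OC)c1)c1ccc(O)c(OC)c1` gives 69000 nM
- compound 3 `COc1cc(C(c2ccc(O)c(OC)c2)[C@@H](C)[C@H](C)CO)ccc1O` gives > 100000 nM

Compound 3 reads > 100000 nM as a limit of the assay and not as a number. Its position is known only through an at least 5.2-fold higher number from compound 1 to compound 3 (0.72 log units; beyond the scatter) and through an at least 1.4-fold higher number from compound 2 to compound 3 (0.16 log units; that floor lies within the scatter) on the same read-out.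

The next entry is compound 4 `COc1cc(C(c2ccc(O)c(OC)c2)[C@H](C)[C@@H](C)CF)ccc1O` and the difference is 2-(fluoromethyl)-1-methylpropyl in place of 2-(hydroxymethyl)-1-methylpropyl on a saturated chain carbon bound to two aromatic carbons with 2-(fluoromethyl)-1-methylpropyl in place of 2-(hydroxymethyl)-1-methylpropyl on a saturated chain carbon bound to two aromatic carbons.

Going by the values given here, two measured steps bear on this change. Leaving 1-(fluoromethyl)-2-methylpropyl gave a 3.6-fold higher number from compound 1 to compound 2 (0.56 log units; beyond the scatter) and also an at least 5.2-fold higher number from compound 1 to compound 3 (0.72 log units; beyond the scatter) in the same direction. Read backwards, they point to a modest move towards a lower number in this assay when fluoromethyl enters. The chain of compound 4 is not that of compound 1, so the size stays uncertain.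

The expected change is an at least 2.8-fold lower number from compound 3 to compound 4 (0.45 log units; beyond the scatter) as a rough estimate. For compound 4 the estimate is 35000 nM with an expected range from 12000 nM to 100000 nM in this assay.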

Compound 4, half-maximal inhibitory concentration: 34000 nM
Beside the measured number, compound 4's estimate is 1.0-fold (0.01 log units) above it; measured number inside the range.
By their numbers in this assay, from the lowest: compounds 1 and 4 (each within the scatter of the next); then compound 2. At a limit, above all of these: compound 3.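

In this assay, going by these compounds alone, the exchange of hydroxymethyl for fluoromethyl on the same chain gives an at least 2.9-fold lower number from compound 3 to compound 4 (0.46 log units; beyond the scatter), a direct reading of a change that the earlier compounds showed only through different chains. Compound 3 reads as a limit of the assay, so this step gives only a floor: the limit of > 100000 nM in this assay, at which 1 of the 4 values shown sits. The two fluorine-bearing chains are not separated, with a 1.8-fold higher number from compound 1 to compound 4 (0.25 log units; within the scatter), a step within the scatter, while 2-(fluoromethyl)-1-methylpropyl against 1-(methoxymethyl)-2-methylpropyl gives a 2.0-fold lower number from compound 2 to compound 4 (0.31 log units; beyond the scatter), just beyond it.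

From the compounds shown here alone, the true size of the step from hydroxymethyl to fluoromethyl stays open. Also open, going by these compounds, is whether a chloromethyl or an aminomethyl group on this chain would read like fluoromethyl, or whether the result is specific to fluorine.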